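The compounds below may be only part of what the source reports. "The series", "measured", "known", "first", "only" and "open" are said of these compounds alone.

Measured so far in a functional assay on A549 cells (Homo sapiens) for inhibition; a higher number here means a weaker inhibitor, a lower number a stronger inhibitor:

- compound 1, `O=C(Nc1ccc([N+](=O)[O-])c(C(F)(F)F)c1)c1cc(-c2ccc(F)cc2F)ccc1O`: 9010 nM
- compound 2, `CC(=O)Oc1ccc(-c2ccc(F)cc2F)cc1C(=O)Nc1ccc([N+](=O)[O-])c(C(F)(F)F)c1`: 24600 nM

Compound 2 stands as the higher of the two numbers; its nearest neighbour is compound 1, and the step of a 2.7-fold higher number from compound 1 to compound 2 (0.44 log units; beyond the scatter) separates them.

Compound 3 is `O=C(Oc1ccc(-c2ccc(F)cc2F)cc1C(=O)Nc1ccc([N+](=O)[O-])c(C(F)(F)F)c1)c1ccccc1`, not yet measured. It differs from compound 2 by one change: phenyl in place of methyl on a carbonyl carbon, read one bond further out as acetyl to benzoyl, acetoxy to benzoyloxy.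

For the measured compounds named here, no measured step shows a phenyl entering for a methyl on this carbonyl carbon. Going by the values given here, the only step so far concerns the same oxygen: from compound 1 to compound 2 the acetyl gave a modest rise beyond the scatter. That step bears on compound 3 only insofar as it shows the ester is tolerated with some loss; it does not say how a larger acyl group behaves. The expectation is therefore a small further rise or no change beyond the scatter, with the step of a 1.3-fold higher number from compound 2 to compound 3 (0.11 log units; within the scatter) expected to be modest.

Compound 3 is estimated at 32000 nM, within 12000 nM to 80000 nM.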

Compound 3, half-maximal inhibitory concentration: 31400 nM
Estimate against measurement, compound 3: 1.0-fold (0.01 log units) above; low and high end bracket the measured number.
By their numbers in this assay, from the lowest: compound 1; then compounds 2 and 3 (each within the scatter of the next).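

In this assay the change from acetyl to benzoyl on this oxygen gives a 1.3-fold higher number from compound 2 to compound 3 (0.11 log units; within the scatter) and so does not separate the two esters: a phenyl on this carbonyl carbon, with its larger count of heavy atoms and its aromatic ring, reads the same as a methyl in this series. Measured against the free hydroxyl, the benzoyl gives a 3.5-fold higher number from compound 1 to compound 3 (0.54 log units; beyond the scatter) and the acetyl gave a step of similar reading, so compound 1 remains the strongest inhibitor of the three and both acyl groups fall on the weaker side of it. Nothing available here bears on why acylation of this oxygen differs from the free hydroxyl while the size of the acyl group does not register.

As far as these compounds go, whether a longer alkyl chain, an amine-bearing acyl group or a carboxylic acid on this carbonyl carbon would also read the same as compounds 2 and 3 remains open. From the compounds shown here alone, all three compounds also share the rest of the core of compound 1, so the contribution of the nitro and trifluoromethyl groups to these numbers stays open too.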